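Chain change on the core of compound 1, KB cells

The source may report more compounds than this note shows. Statements on the series, on what has been measured and on what is new or still open speak of the compounds shown alone.

For the measured compounds named here, compound 1 `CCCn1cc(C(N)=O)c2c(N)ncnc21` gives 100000 nM in a functional assay on KB cells (Homo sapiens) for cytotoxicity (a higher number here means a weaker inhibitor, a lower number a stronger inhibitor), the highest of the three numbers measured so far. Compound 2 `CCCn1cc(C(=N)S)c2c(N)ncnc21` gives 17000 nM in this assay, and compound 3 `C=CCn1cc(C(N)=S)c2c(N)ncnc21` gives 19000 nM; each of the two stands below compound 1 by more than the scatter. Going by the values given here, the only single-point step measured, a 5.9-fold lower number from compound 1 to compound 2 (0.77 log units; beyond the scatter), alters the group on the aromatic carbon and leaves the chain on the aromatic nitrogen untouched. Compound 3 differs from compound 1 in two places at once, so its numbers say nothing separately about the chain.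

Compound 4 `COCCOCn1cc(C(N)=O)c2c(N)ncnc21` differs from compound 1 by 2-methoxyethoxy in place of ethyl on a saturated chain carbon bound to an aromatic nitrogen. Among the compounds with values here, no measured step bears on this change: nothing so far varies the chain alone. With no evidence either way, no step beyond the scatter is expected in this assay, and the estimated step is no change at the digits printed from compound 1 to compound 4 (within the scatter). Compound 4 is therefore estimated at 100000 nM, with a range from 30000 nM to 300000 nM.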

Compound 4, half-maximal inhibitory concentration: > 100000 nM
Compound 4: only a limit was reported (the forecaster's own chance of this, stated with the estimate: 35%); the middle value sits exactly at the limit.
By their numbers in this assay, from the lowest: compounds 2 and 3 (each within the scatter of the next); then compound 1.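

In this assay compound 4 is reported only as a limit, > 100000 nM. For the compounds shown here, this is the first change that touches the chain on the aromatic nitrogen alone: 2-methoxyethoxy in place of ethyl gives a number no lower from compound 1 to compound 4 (the limit leaves the size open), so this swap shows no gain on the core of compound 1. The size of the step stays unread because compound 1 already sits at the figure of this limit: the limit of > 100000 nM in this assay, at which 1 of the 4 values shown sits.

Open, on these data alone, is whether a chain ending in an amine or a carboxylic acid, or a longer plain alkyl chain, at this place would shift the number from compound 1 by more than the scatter. Open too, as far as these compounds go, is how the same chain change would read starting from compound 2, which gives 17000 nM.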